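From 4-ethylphenyl to 4-methylphenyl on the amine nitrogen

A few compounds are considered here, and "the series" means these few. Any claim that something is new, unique, unknown or untested is made for them only; others in the source may bear on it.

In a functional assay on MCF7 cells (Homo sapiens) for inhibition, read by sulforhodamine B assay (a higher number here means a weaker inhibitor, a lower number a stronger inhibitor), compound 1 (`O=C1C(NC2CCCC2)=CC(=O)c2c1nc1n2[C@H]2OC[C@@H](O)[C@H]2OC1`), with cyclopentyl on the amine nitrogen, gives > 16000 nM as its reading, a limit of the assay and not a number. Compound 2 (`O=C1C(Nc2ccc(Br)cc2)=CC(=O)c2c1nc1n2[C@H]2OC[C@@H](O)[C@H]2OC1`), with 4-bromophenyl, gives 4330 nM and compound 3 (`CCc1ccc(NC2=CC(=O)c3c(nc4n3[C@H]3OC[C@@H](O)[C@H]3OC4)C2=O)cc1`), with 4-ethylphenyl, gives 8990 nM as the higher of the two actual numbers. The steps away from cyclopentyl are an at least 3.6-fold lower number from compound 1 to compound 2 (0.56 log units; beyond the scatter) and an at least 1.7-fold lower number from compound 1 to compound 3 (0.25 log units; that floor lies within the scatter) but both rest on that limit and neither touches the ethyl group.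

Compound 4 (`Cc1ccc(NC2=CC(=O)c3c(nc4n3[C@H]3OC[C@@H](O)[C@H]3OC4)C2=O)cc1`) carries 4-methylphenyl instead, the change being hydrogen in place of methyl on a saturated chain carbon bound to an aromatic carbon. The closest measured precedent is a 2.1-fold higher number from compound 2 to compound 3 (0.32 log units; beyond the scatter) for ethyl in place of bromo on an aromatic carbon, and that step is only modest. With ethyl going to methyl, no step beyond the scatter is expected in this assay and no firm direction can be assigned. The expected step is a 1.2-fold lower number from compound 3 to compound 4 (0.08 log units; within the scatter) and it stays within the scatter. For compound 4 the estimate is 7500 nM with an expected range from 3800 nM to 15000 nM for the measurement.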

Compound 4, half-maximal inhibitory concentration: > 4000 nM
Compound 4: only a limit was reported (the forecaster's own chance of this, stated with the estimate: 12%); the middle value is on the limit's open side.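

In this assay compound 4 gives > 4000 nM, a limit and not a number. The steps to compound 4 from compound 1, compound 2 and compound 3 therefore cannot be read. The compounds shown leave open whether 4-methylphenyl and 4-ethylphenyl on the amine nitrogen differ at all in this assay.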